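Cyclopropyl for 2-methoxyphenyl on the amine nitrogen

The source may hold more compounds than are shown below. What is called first, only, known or untested is meant among the compounds shown, and "the series" means these compounds.

In a functional assay on MCF7 cells (Homo sapiens) for inhibition, read by sulforhodamine B assay (on this read-out higher numbers stand for weaker inhibition and lower numbers for stronger inhibition), compound 1 `Cc1ccc(NC2=CC(=O)c3c(nc4n3[C@H]3OC[C@@H](O)[C@H]3OC4)C2=O)cc1` gives > 4000 nM, which is a limit and not a number. Steps starting from compound 1 therefore cannot be sized. Compound 3 `COc1ccccc1NC1=CC(=O)c2c(nc3n2[C@H]2OC[C@@H](O)[C@H]2OC3)C1=O` gives 6580 nM and compound 2 `Cc1ccc(NC2=CC(=O)c3c(nc4n3[C@H]3OC[C@@H](O)[C@H]3OC4)C2=O)cc1C` gives 4950 nM, so the two stand together: a 1.3-fold higher number from compound 2 to compound 3 (0.12 log units; within the scatter). Compound 4 `O=C1C(NC2CC2)=CC(=O)c2c1nc1n2[C@H]2OC[C@@H](O)[C@H]2OC1` carries cyclopropyl in place of 2-methoxyphenyl on an amine nitrogen, cyclopropyl in place of 2-methoxyphenyl on an amine nitrogen. Among the compounds with values here, the only readable step, a 1.3-fold higher number from compound 2 to compound 3 (0.12 log units; within the scatter), exchanges one substituted phenyl for another, so it is a weak guide to this change. No step beyond the scatter is expected in this assay, and no direction is favoured. The expected step is a 1.1-fold lower number from compound 3 to compound 4 (0.04 log units; within the scatter). Compound 4 is estimated at 6000 nM, with an expected range of 2500 nM to 15000 nM.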

Compound 4, half-maximal inhibitory concentration: > 16000 nM
Compound 4 gave a limit, no number; the forecaster's own chance of this, stated with the estimate: 30%; middle value at least 2.6-fold (0.42 log units) from the limit.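

In this assay compound 4 gives > 16000 nM, which is a limit and not a number. Even so, this position on the amine nitrogen now shows a change beyond the scatter, which the two substituted phenyl groups did not: cyclopropyl gives an at least 2.4-fold higher number from compound 3 to compound 4 (0.38 log units; beyond the scatter) and an at least 3.2-fold higher number from compound 2 to compound 4 (0.50 log units; beyond the scatter). The step from compound 1 to compound 4 cannot be read, as both values are limits.

Cyclopropyl differs from the phenyl groups in both ring type and size, and the compounds shown do not separate the two. Cyclohexyl or benzyl on the same nitrogen would bear on this.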